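Ether in place of thioester: what to expect for compound 4

A few compounds are considered here, and "the series" means these few. Any claim that something is new, unique, unknown or untested is made for them only; others in the source may bear on it.

Measured so far in a functional assay on SK-BR-3 cells (Homo sapiens) for cytotoxicity, read by MTT assay, with a stated time of 72 h; a lower number here means that less compound is needed, a higher number that more compound is needed for the effect: compound 1 `CCc1cccc2c(OC)c(-c3occ(C)c3C(=S)OC)ccc12`, 6.3 ug/mL; compound 2 `CCOc1c(-c2occ(C)c2C(=O)OC)ccc2c(CC)cccc12`, 1.9 ug/mL; compound 3 `CCOc1c(-c2occ(C)c2CO)ccc2c(CC)cccc12`, 8.8 ug/mL.

Compound 1 stands second highest of the three numbers in this assay: its gap to compound 3 lies within the scatter, while compound 2 sits lower, beyond the scatter. Compound 4 `CCOCc1c(C)coc1-c1ccc2c(CC)cccc2c1OC` differs from compound 1 by a group of 4 heavy atoms (3 carbon, 1 oxygen; no ring) in place of a group of 4 heavy atoms (2 carbon, 1 oxygen, 1 sulfur; no ring), on an aromatic carbon. For the measured compounds named here, the only measured step that bears on this, a 4.6-fold higher number from compound 2 to compound 3 (0.67 log units; beyond the scatter), likewise exchanges a carbonyl-type group for a carbon bearing a single oxygen. Going by the values given here, compound 4 is therefore expected to need more compound than compound 1, a step of a 2.2-fold higher number from compound 1 to compound 4 (0.35 log units; beyond the scatter), though no measured pair carries an ethoxymethyl group. The estimate for compound 4 is 14 ug/mL, with a range from 5 ug/mL to 35 ug/mL.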

Compound 4, concentration for half-maximal effect: > 10 ug/mL
Compound 4 gave a limit, no number (the forecaster's own chance of this, stated with the estimate: 10%); the middle value does not contradict the limit.
By their numbers in this assay, from the lowest: compound 2; then compounds 1 and 3 (each within the scatter of the next). At a limit, above all of these: compound 4.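

In this assay compound 4 gives > 10 ug/mL, which is a limit and not a number. Ethoxymethyl in place of the sulfur-bearing group on this aromatic carbon gives an at least 1.5-fold higher number from compound 1 to compound 4 (0.20 log units; that floor lies within the scatter), so only the floor of the step is known. The earlier compounds shown here held no ether at this position, and this result shows that one does not bring the number down from that of compound 1.

Going by these compounds, the actual value of compound 4 remains open. So does how an amine or a carboxylic acid would read on this aromatic carbon.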